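A Second Methoxy Group on Compound 1

The source may report more compounds than this note shows. Statements on the series, on what has been measured and on what is new or still open speak of the compounds shown alone.

Compound 1 `COc1cccc(/C=C2\CCC=CC2=O)c1` gives 1060 nM
Compound 2 `COc1ccc(/C=C2\CCC=CC2=O)cc1OC` gives 640 nM
Compound 3 `COc1cccc(/C=C2\CCC=CC2=O)c1OC` gives 610 nM

In a functional assay on MDA-MB-231 cells (Homo sapiens) for antiproliferative activity, read by sulforhodamine B assay, with a stated time of 72 h (a higher number here means a weaker inhibitor, a lower number a stronger inhibitor), compound 1 gives 1060 nM as the highest of the three numbers, although the other two stay within the scatter of it. Compound 4 `COc1cc(/C=C2\CCC=CC2=O)cc(OC)c1` differs from compound 1 by one change: methoxy in place of hydrogen on an aromatic carbon and nothing else. Two measured steps make the same swap of methoxy in place of hydrogen on an aromatic carbon: a 1.7-fold lower number from compound 1 to compound 2 (0.22 log units; within the scatter) and a 1.7-fold lower number from compound 1 to compound 3 (0.24 log units; within the scatter) and both stay within the scatter. In this assay a small move toward a lower number is therefore expected, but none beyond the scatter. Compound 4 is estimated at 700 nM with 350 nM to 1400 nM as its expected range. That estimate amounts to a 1.5-fold lower number from compound 1 to compound 4 (0.18 log units; within the scatter) as the expected step.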

Compound 4, half-maximal inhibitory concentration: 600 nM
The estimate for compound 4 lay 1.2-fold (0.07 log units) above the measured number; low and high end bracket the measured number.
By their numbers in this assay, from the lowest: compounds 4, 3, 2 and 1 (each within the scatter of the next).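

In this assay, a methoxy placed meta to a methoxy group brings a 1.8-fold lower number from compound 1 to compound 4 (0.25 log units; within the scatter), so this third place on the ring behaves like the two earlier swaps, with every step staying within the scatter. Across these three steps, the place of the second methoxy makes no clear difference to the number. No measurement is available to explain why the steps are this small.

The compounds shown leave open whether an amine, a carboxylic acid or a longer chain at this place would move the number beyond the scatter.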